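Isopropyl in Place of Propyl on the Shared Core

A few compounds are considered here, and "the series" means these few. Any claim that something is new, unique, unknown or untested is made for them only; others in the source may bear on it.

Compound 1 `CCCCCCc1cn([C@H]2C[C@@H]3OP(=O)(O)OC[C@H]3O2)c(=O)[nH]c1=O` in a functional assay on L1210 cells (Mus musculus); on this read-out lower numbers stand for stronger inhibition and higher numbers for weaker inhibition: > 500 ug/mL, a limit of the assay rather than a number.
Compound 2 `CCCc1cn([C@H]2C[C@@H]3OP(=O)(O)OC[C@H]3O2)c(=O)[nH]c1=O` in this assay: > 500 ug/mL, likewise a limit.

Compound 2 therefore stands at the assay limit, and every value shown shares that position, as the limit of > 500 ug/mL in this assay, at which 2 of the 2 values shown sit, records. For the measured compounds named here, the step that the two limits leave unreadable from compound 1 to compound 2 cannot be read, so no measured step gives a size or direction. Compound 3 `CC(C)c1cn([C@H]2C[C@@H]3OP(=O)(O)OC[C@H]3O2)c(=O)[nH]c1=O` differs from compound 2 by isopropyl in place of propyl on an aromatic carbon. With both neighbours at the limit, compound 3 is expected to remain there as well, giving an expected step that the limit leaves unreadable from compound 2 to compound 3. The estimate for compound 3 in this assay is 800 ug/mL, ranging from 300 ug/mL to 3000 ug/mL.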

Compound 3, concentration for 50% inhibition: > 500 ug/mL
Compound 3 was reported as a limit; the forecaster's own chance of this, stated with the estimate: 85%; the middle value is on the limit's open side.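

For the compounds shown here, compound 3 stays at a limit of the assay, as do compound 1 and compound 2, so no step among them can be read: the limit of > 500 ug/mL in this assay, at which 3 of the 3 values shown sit.

In this assay the compounds shown leave open whether any of these chains on the shared core differs from another in inhibition.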